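The source may hold more compounds than are shown below. What is called first, only, known or untested is meant among the compounds shown, and "the series" means these compounds.

Compound 1: `COc1ccc(/C=C/C(=O)Nc2ccc3ncnc(Nc4cccc(Br)c4)c3c2)cc1` – 3.36 ug/mL
Compound 2: `COc1ccccc1/C=C/C(=O)Nc1ccc2ncnc(Nc3cccc(Br)c3)c2c1` – 3.55 ug/mL
Compound 3: `O=C(/C=C/c1ccc(Cl)cc1)Nc1ccc2ncnc(Nc3cccc(Cl)c3)c2c1` – 12.4 ug/mL

In a functional assay on A549 cells (Homo sapiens) for antiproliferative activity, read by MTT assay, with a stated time of 48 h (on this read-out higher numbers stand for weaker inhibition and lower numbers for stronger inhibition), compound 3 gives 12.4 ug/mL and stands highest of the three numbers; compound 2 gives 3.55 ug/mL and compound 1 gives 3.36 ug/mL, both lower than compound 3 by more than the scatter. Compound 4, `O=C(/C=C/c1ccc([N+](=O)[O-])cc1)Nc1ccc2ncnc(Nc3cccc(Cl)c3)c2c1`, differs from compound 3 by nitro in place of chloro on an aromatic carbon. Going by the values given here, the only measured step, a 1.1-fold higher number from compound 1 to compound 2 (0.02 log units; within the scatter), moves a methoxy group to another position on the same ring and lies within the scatter; it says nothing about exchanging chloro for nitro, and no measured pair shows that exchange. Compounds 1 and 2 also differ from compound 3 in more than one place, so their values cannot be tied to the chloro group alone. Among the compounds with values here, with no step that bears on the change, no shift beyond the scatter is expected, and the expected step is a 1.2-fold lower number from compound 3 to compound 4 (0.09 log units; within the scatter). Compound 4 is therefore estimated at 10 ug/mL, with a range from 4 ug/mL to 25 ug/mL.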

Compound 4, half-maximal inhibitory concentration: 5.26 ug/mL
Compound 4: the middle estimate sits 1.9-fold (0.28 log units) above what was measured, and the stated range covers the measured number.
By their numbers in this assay, from the lowest: compounds 1, 2 and 4 (each within the scatter of the next); then compound 3.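

In this assay, exchanging the 4-chlorophenyl for a 4-nitrophenyl gives a 2.4-fold lower number from compound 3 to compound 4 (0.37 log units; beyond the scatter) in a modest step. Going by these compounds alone, this is the first change at a single place in this set to move the number beyond the scatter, since the only earlier step, a 1.1-fold higher number from compound 1 to compound 2 (0.02 log units; within the scatter), shifted a methoxy group around its ring and stayed within it. Within the data shown here, the aromatic carbon para to a large group is therefore a place where the number responds when chloro gives way to nitro, although one exchange shows only that this pair differs and sets no trend.

On these data alone, whether another group here, such as an amine or a nitrile, would lower the number further or raise it remains open, as does whether the same exchange would give a similar step in a compound carrying bromo instead of chloro. Nothing measured here says why the number moved.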